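This account rests on a few compounds, and the source may have more. Where it says the series, first, only, none or still open, it means among the compounds named here.

Among the compounds with values here, compound 1, `CC(O)(C[S+]([O-])c1ccc(F)cc1F)C(=O)Nc1ccc([N+](=O)[O-])cc1C(F)(F)F`, is the only compound here with a numerical result: in a functional assay on CWR22R cells (Homo sapiens) for antiproliferative activity (a higher number here means a weaker inhibitor, a lower number a stronger inhibitor), compound 1 gives 51100 nM. Compound 2, `CC(O)(C[S+]([O-])c1ccccn1)C(=O)Nc1ccc(C#N)c(C(F)(F)F)c1`, sits at the limit of > 100000 nM in this assay, at which 1 of the 2 values shown sits; compound 2 gives > 100000 nM, a limit and not a number. Compound 3, `CC(O)(C[S+]([O-])c1ccccc1OC(F)(F)F)C(=O)Nc1ccc([N+](=O)[O-])cc1C(F)(F)F`, differs from compound 1 by 2-(trifluoromethoxy)phenyl in place of 2,4-difluorophenyl on a sulfur. Within the data shown here, no step between measured compounds is available, so the step from compound 1 to compound 3 is expected to stay within the usual scatter, at a 1.2-fold higher number from compound 1 to compound 3 (0.07 log units; within the scatter), since compound 1 already gives 51100 nM. Compound 3 is therefore estimated at 60000 nM, with a range from 15000 nM to 150000 nM.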

Compound 3, half-maximal inhibitory concentration: 15200 nM
Compound 3: the middle estimate sits 3.9-fold (0.60 log units) above what was measured, and the stated range covers the measured number.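

In this assay, putting 2-(trifluoromethoxy)phenyl in place of 2,4-difluorophenyl on the sulfur gives a 3.4-fold lower number from compound 1 to compound 3 (0.53 log units; beyond the scatter), so a stronger inhibitor results. Within the data shown here, this is the first direct evidence that this position responds to the group placed there, since the earlier compounds offered no pair differing in one place. Nothing shown here explains the change.

The two groups differ in more than one feature, so this single step cannot show which feature matters. Going by these compounds, how a plain phenyl or a ring carrying an amine would behave at this position remains open.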